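Swapping the aryl group on a fluorinated compound

This account rests on a few compounds, and the source may have more. Where it says the series, first, only, none or still open, it means among the compounds named here.

Results in a functional assay on HT-29 cells (Homo sapiens) for inhibition, read by CCK-8 assay, with a stated time of 24 h; a higher number here means a weaker inhibitor, a lower number a stronger inhibitor:
- compound 1 `Cc1cccc(-n2cc(-c3ccc(/C=C4\C(=O)Nc5ccccc54)cc3)nn2)c1`: 3940 nM
- compound 2 `O=C1Nc2ccccc2/C1=C/c1ccc(-c2cn(-c3ccc(F)cc3)nn2)cc1`: 17700 nM
- compound 3 `Cc1cccc(-n2cc(-c3ccc(/C=C4\C(=O)Nc5ccc(F)cc54)cc3)nn2)c1`: 7320 nM
- compound 4 `O=C1Nc2ccc(F)cc2/C1=C/c1ccc(-c2cn(-c3ccc(F)cc3)nn2)cc1`: not yet measured

Compound 3 sits within the scatter of compound 1, while compound 2 has a higher number, beyond the scatter. Going to compound 4 changes the group on an aromatic nitrogen: 4-fluorophenyl in place of 3-methylphenyl on an aromatic nitrogen. Going by the values given here, the same swap gave a 4.5-fold higher number from compound 1 to compound 2 (0.65 log units; beyond the scatter), a modest step and the closest precedent. The fluoro change, a 1.9-fold higher number from compound 1 to compound 3 (0.27 log units; within the scatter), stayed within the scatter and is already present in compound 3. A similar rise is therefore expected, and the estimated step is a 3.8-fold higher number from compound 3 to compound 4 (0.58 log units; beyond the scatter). For compound 4 the expected value is 28000 nM, within an estimated range of 11000 nM to 70000 nM.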

Compound 4, half-maximal inhibitory concentration: 20000 nM
Estimate against measurement, compound 4: 1.4-fold (0.15 log units) above; the measured number falls inside the stated range.
By their numbers in this assay, from the lowest: compounds 1 and 3 (each within the scatter of the next); then compounds 2 and 4 (each within the scatter of the next).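

In this assay, the swap to 4-fluorophenyl on the aromatic nitrogen also raises the number on the fluorinated core, giving a 2.7-fold higher number from compound 3 to compound 4 (0.44 log units; beyond the scatter), and the step agrees with the one on the unfluorinated core: the same change on two cores in this assay, a 4.5-fold higher number (0.65 log units; beyond the scatter) from compound 1 to compound 2 and a 2.7-fold higher number (0.44 log units; beyond the scatter) from compound 3 to compound 4, 1.6-fold (0.22 log units) apart, within the scatter of two such steps. The fluoro on the core gives a 1.1-fold higher number from compound 2 to compound 4 (0.05 log units; within the scatter), so it stays within the scatter with either aryl group: the same change on two cores in this assay, a 1.9-fold higher number (0.27 log units; within the scatter) from compound 1 to compound 3 and a 1.1-fold higher number (0.05 log units; within the scatter) from compound 2 to compound 4, 1.6-fold (0.22 log units) apart, within the scatter of two such steps. Still open, from the compounds shown here alone, is whether the step comes from losing the methyl or gaining the fluorine, a question that a plain phenyl group on this nitrogen could help separate.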